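Compound 4 and the cytotoxicity limit

This account rests on a few compounds, and the source may have more. Where it says the series, first, only, none or still open, it means among the compounds named here.

Values so far in an ADME assay on RAW264.7 cells (Mus musculus) for cytotoxicity, read by neutral red uptake, with a stated time of 24 h (on this read-out lower numbers stand for higher toxicity in this test and higher numbers for lower toxicity in this test), each of them a limit of the assay
Compound 1 (`CC(C(=O)NOCc1ccccc1)N1C(=O)S/C(=C\c2ccc(C(F)(F)F)cc2)C1=O`) gives a limit (> 128000 nM)
Compound 2 (`CC(C(=O)NOCc1ccccc1)N1C(=O)S/C(=C\c2ccc(F)cc2)C1=O`) gives a limit (> 128000 nM)
Compound 3 (`C=CCONC(=O)C(C)N1C(=O)S/C(=C\c2ccc(F)cc2)C1=O`) gives a limit (> 128000 nM)

Compound 2 is known only by a limit (> 128000 nM) and not by a number. The other two compounds stand at the same place (the limit of > 128000 nM in this assay, at which 3 of the 3 values shown sit).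

The change to compound 4 (`CCCC/C=C1\SC(=O)N(C(C)C(=O)NOCc2ccccc2)C1=O`) is a single one (butyl in place of 4-fluorophenyl on a double-bonded chain carbon bound to a double-bonded ring carbon), with butyl in place of 4-fluorophenyl on a double-bonded chain carbon bound to a double-bonded ring carbon.

Within the data shown here, two measured steps bear on it, though only loosely, and neither has a readable size. The first (a step that the two limits leave unreadable from compound 1 to compound 2) has fluoro in place of trifluoromethyl on an aromatic carbon. The second (a step that the two limits leave unreadable from compound 2 to compound 3) has vinyl in place of phenyl on a saturated chain carbon bound to an oxygen. Neither of these changes the group that leaves here.

Since compound 2 holds a limit (> 128000 nM) no step beyond the scatter is expected in this assay, in either direction. The expected step (a number no higher from compound 2 to compound 4 (the limit leaves the size open)) is an estimate set against a limit. The estimate for compound 4 is 128000 nM ( expected range 64000 nM to 256000 nM), and the assay will most likely report a limit again.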

Compound 4, half-maximal cytotoxic concentration: 43900 nM
For compound 4 the middle estimate is 2.9-fold (0.46 log units) above the measured one; measured number below the stated range.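

At the double-bonded chain carbon bound to a double-bonded ring carbon, butyl in place of 4-fluorophenyl gives in this assay an at least 2.9-fold lower number from compound 2 to compound 4 (0.46 log units; beyond the scatter). Butyl in place of 4-(trifluoromethyl)phenyl at the same place gives an at least 2.9-fold lower number from compound 1 to compound 4 (0.46 log units; beyond the scatter), so the same outcome is seen from both aromatic starting points, and this position is the first shown at which a change moves the read-out beyond the scatter. Compound 4 is the only compound shown with a number rather than a limit of the assay, and the earlier steps, which run from one limit to another, cannot be read: the limit of > 128000 nM in this assay, at which 3 of the 4 values shown sit.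

The true size of both new steps stays open, since each starts from a limit, and the compounds shown do not separate the loss of the aromatic ring from the presence of the butyl chain. Also open, going by these compounds, is whether a cyclohexyl ring or a longer chain such as octyl at this place, or the allyl group of compound 3 paired with butyl, would give a number or return to the limit.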